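Replacing Cyclopentyl on a Carbonyl Carbon in Compound 2

The compounds below may be only part of what the source reports. "The series", "measured", "known", "first", "only" and "open" are said of these compounds alone.

Measured in an in vivo functional assay on the whole organism (MDA-MB-435 cells, Homo sapiens) for antiproliferative activity; on this read-out lower numbers stand for stronger inhibition and higher numbers for weaker inhibition:
- Compound 1 `CO[C@@H](C(=O)NC1CC[C@@H](OC(=O)/C=C/c2ccccc2)CNC1=O)[C@H](O)[C@@H](O)[C@H](O)/C=C/C(C)(C)C`: 20 nM
- Compound 2 `CO[C@@H](C(=O)NC1CC[C@@H](OC(=O)C2CCCC2)CNC1=O)[C@H](O)[C@@H](O)[C@H](O)/C=C/C(C)(C)C`: 130 nM

Of these two compounds, compound 2 has the higher number. Compound 3 `CO[C@@H](C(=O)NC1CC[C@@H](OC(=O)CCc2cccnc2)CNC1=O)[C@H](O)[C@@H](O)[C@H](O)/C=C/C(C)(C)C` is not yet measured and differs from compound 2 as follows: 2-(pyridin-3-yl)ethyl in place of cyclopentyl on a carbonyl carbon. Within the data shown here, only one measured step changes a group at this place, a 6.5-fold higher number from compound 1 to compound 2 (0.81 log units; beyond the scatter). Compound 1 carries 2-phenylethenyl there, and compound 3 also has an aromatic ring in that group, so a lower number is expected, though a smaller step than that one. The expected step is a 2.2-fold lower number from compound 2 to compound 3 (0.34 log units; beyond the scatter). The estimate for compound 3 is 60 nM, with an estimated range of 20 nM to 200 nM.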

Compound 3, half-maximal inhibitory concentration: 460 nM
Beside the measured number, compound 3's estimate is 7.7-fold (0.88 log units) below it; the whole stated range lies below it.
By their numbers in this assay, from the lowest: compound 1; then compound 2; then compound 3.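

In this assay the carbonyl-carbon position proves to need more than an aromatic ring, since 2-(pyridin-3-yl)ethyl in place of cyclopentyl gives weaker inhibition (a 3.5-fold higher number from compound 2 to compound 3 (0.55 log units; beyond the scatter)). Set against 2-phenylethenyl, the same group gives a larger loss (a 23-fold higher number from compound 1 to compound 3 (1.36 log units; beyond the scatter)), so the stronger inhibition of compound 1 does not follow from having a ring in this group alone. No evidence at hand explains either step.

Compound 3 differs from compound 1 in both its ring and its chain, and the compounds shown do not separate these two changes. A 2-phenylethyl or a 2-(pyridin-3-yl)ethenyl group at this position would bear on that question.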